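Compound 3 to compound 4: replacing the tetrazolyl cyclohexyl

The source may report more compounds than this note shows. Statements on the series, on what has been measured and on what is new or still open speak of the compounds shown alone.

In an ADME assay on microsomes from liver (Homo sapiens) for metabolic stability, with a stated time of 10 min (a higher number here means that more of the compound is left, a lower number that less of the compound is left), compound 3 `O=C([C@H]1CC[C@H](c2nnn[nH]2)CC1)N1CC[C@](c2ccc(C(F)(C(F)(F)F)C(F)(F)F)cc2)(S(=O)(=O)c2ccc(F)cc2)C1` gives 100% and compound 1 `C[C@]1(C(=O)O)CC[C@H](C(=O)N2CC[C@](c3ccc(C(F)(C(F)(F)F)C(F)(F)F)cc3)(S(=O)(=O)c3ccc(F)cc3)C2)CC1` gives 97%, two values within the scatter of each other, while compound 2 `C[C@]1(C(=O)N2CC[C@](c3ccc(C(F)(C(F)(F)F)C(F)(F)F)cc3)(S(=O)(=O)c3ccc(F)cc3)C2)CC[C@H](C(=O)O)CC1` gives 80%. The next change leads to compound 4 `CCC1(C(=O)N2CC[C@](c3ccc(C(F)(C(F)(F)F)C(F)(F)F)cc3)(S(=O)(=O)c3ccc(F)cc3)C2)CCS(=O)(=O)CC1`: 4-ethyl-1,1-dioxothian-4-yl in place of 4-(1H-tetrazol-5-yl)cyclohexyl on a carbonyl carbon. Within the data shown here, no measured compound carries the entering group. The nearest evidence is the set of changes at the same place: a number 3 percentage points higher from compound 1 to compound 3 (within the scatter), a number 17 percentage points lower from compound 1 to compound 2 (beyond the scatter) and a number 20 percentage points higher from compound 2 to compound 3 (beyond the scatter). With compound 3 at 100%, little room remains upward, so a modest fall is expected, a number 12 percentage points lower from compound 3 to compound 4 (beyond the scatter). For compound 4 the estimate is 88%, with an expected range of 68% to 100%.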

Compound 4, percent of the compound remaining: 3%
Beside the measured number, compound 4's estimate is 85 percentage points above it; the measured number lies below the stated range.
By their numbers in this assay, from the lowest: compound 4; then compound 2; then compounds 1 and 3 (each within the scatter of the next).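

In this assay, among these compounds, this position proves far from tolerant: entry of 4-ethyl-1,1-dioxothian-4-yl gives a number 97 percentage points lower from compound 3 to compound 4 (beyond the scatter), a number 77 percentage points lower from compound 2 to compound 4 (beyond the scatter) and a number 94 percentage points lower from compound 1 to compound 4 (beyond the scatter), each much larger than any step among the earlier compounds. Compound 4 is the only one shown with neither a carboxy nor a 1H-tetrazol-5-yl group, and the only one with a hetero atom in this six-membered ring. Nothing available accounts for this loss.

Which feature carries the drop remains open. A carboxylic acid on the dioxothian ring, or a methyl in place of the ethyl, would help separate them.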